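Cytotoxicity notes: fluoro to methyl on the aryl ring

This account rests on a few compounds, and the source may have more. Where it says the series, first, only, none or still open, it means among the compounds named here.

Compound 1, `COc1ccc(C2=Cc3ccc(F)cc3C(CC(C)=O)N2c2ccc(F)cc2)cc1`: in an ADME assay on TZM cells (Homo sapiens) for cytotoxicity, read by CellTiter-Glo, with a stated time of 48 h (a higher number here means that more compound is tolerated, a lower number that less compound is tolerated), compound 1 gives "not determined" (no result reported).
Compound 2, `COc1ccc(C2=Cc3ccc([N+](=O)[O-])cc3C(CC(C)=O)N2c2ccc(F)cc2)cc1`: in this assay compound 2 gives 7700 nM.

For the measured compounds named here, compound 2 holds the only number in this assay; compound 1 carries no result, so no step between measured compounds can be drawn. Compound 3, `COc1ccc(C2=Cc3ccc([N+](=O)[O-])cc3C(CC(C)=O)N2c2ccc(C)cc2)cc1`, differs from compound 2 by methyl in place of fluoro on an aromatic carbon. Going by the values given here, with no measured step to lean on, the expected step of a 1.3-fold lower number from compound 2 to compound 3 (0.11 log units; within the scatter) is taken as none beyond the scatter, if anything a touch lower. Compound 3 is therefore estimated at 6000 nM, with a range from 2500 nM to 15000 nM.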

Compound 3, half-maximal cytotoxic concentration: 10600 nM
Compound 3: middle estimate off by 1.8-fold (0.25 log units), on the low side; low and high end bracket the measured number.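

In this assay, the change from 4-fluorophenyl to 4-methylphenyl gives a 1.4-fold higher number from compound 2 to compound 3 (0.14 log units; within the scatter), so at this position methyl and fluoro cannot be told apart. For the compounds shown here, this is the first measured step, and it rests on a single pair sharing the nitro group on the core. No supporting measurement is available to interpret it.

As far as these compounds go, whether an amine, a carboxylic acid or a longer chain at this position would move the number beyond the scatter remains open. Also open, from the compounds shown here alone, is whether the same change reads alike with another group in place of the nitro group.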